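A few compounds are considered here, and "the series" means these few. Any claim that something is new, unique, unknown or untested is made for them only; others in the source may bear on it.

The series comprises compound 1, `C=C1CC(c2ccccc2)OC1=O`, compound 2, `C=C1C(=O)O[C@H](c2ccc(OC)cc2)[C@H]1c1ccccc1`, and compound 3, `C=C1C(=O)O[C@H](c2ccc(C(F)(F)F)cc2)[C@H]1c1ccccc1`. In a functional assay on PANC-1 cells (Homo sapiens) for cytotoxicity, read by MTT assay, with a stated time of 72 h, tested at 10 uM (a lower number here means a stronger effect, a higher number a weaker effect of the compound at the concentration tested), compound 1 gives 135%, whereas compound 2 gives 0%. Among the two numbers measured so far compound 2 stands lowest; its nearest neighbour is compound 1, whose value lies higher by a margin beyond the scatter. Compound 3 differs from compound 2 in a single place: trifluoromethyl in place of methoxy on an aromatic carbon. Within the data shown here, no pair of measured compounds carries this change, so the numbers in hand say nothing about how trifluoromethyl in place of methoxy on the aromatic carbon moves the read-out in this assay. The change is expected to produce only a small step, a number 10 percentage points higher from compound 2 to compound 3 (within the scatter), if anything toward a weaker effect. For compound 3 in this assay the estimate is 10%, within a range from 0% to 60%.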

Compound 3, a percentage reported as activity, at one concentration (the size of the read-out at that concentration, not a potency): 33%
For compound 3 the middle estimate is 23 percentage points below the measured one; measured number inside the range.
By their numbers in this assay, from the lowest: compound 2; then compound 3; then compound 1.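

Trifluoromethyl in place of methoxy on the aromatic carbon para to a large group gives the first readable step in the series: in this assay the read-out moves by a number 33 percentage points higher from compound 2 to compound 3 (beyond the scatter). The position is therefore not silent, and within this pair methoxy goes with the stronger effect at the concentration tested, while compound 3 at 33% shows that the effect is reduced, not abolished. Nothing in hand bears on why the read-out moves with this change.

Among these compounds, with only two groups read at this carbon, it remains open whether the step is specific to trifluoromethyl or follows any departure from methoxy. An amine, a carboxylic acid or a longer alkoxy chain at the same carbon would show how far the read-out tracks the group placed there.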